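The source may report more compounds than this note shows. Statements on the series, on what has been measured and on what is new or still open speak of the compounds shown alone.

Compound 1, `COc1ccc(OCCOc2ccc3[nH]c(=O)n(C(C)C)c3c2)cc1`, gives 15.5% in an assay on cells for inhibition of Amine oxidase [flavin-containing] B (Homo sapiens), read by fluorescence, with stated times of 30 min and 15 min, tested at 1 uM; on this read-out higher numbers stand for more inhibition at the one concentration tested (going by the name of the read-out) and lower numbers for less inhibition.
Compound 2, `CCn1c(=O)[nH]c2ccc(OCCOc3ccc(C(C)C)cc3)cc21`, gives 19%.
Compound 3, `CC(C)n1c(=O)[nH]c2ccc(OCCOc3ccc(Cl)cc3)cc21`, gives 18.2%.

On these three numbers, compound 3 sits with the other two: its figure is within the usual scatter of compound 2 and of compound 1, so none of the three can be told apart. Among the compounds with values here, the single one-place step among the measured compounds, a number 2.7 percentage points higher from compound 1 to compound 3 (within the scatter), is likewise within the scatter.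

Compound 4 is `CC(C)c1ccc(OCCOc2ccc3[nH]c(=O)n(C(C)C)c3c2)cc1`. Compared with compound 3 it has isopropyl in place of chloro on an aromatic carbon. Within the data shown here, the one measured step that touches this position is a number 2.7 percentage points higher from compound 1 to compound 3 (within the scatter), which exchanged a different pair of groups at the same aromatic carbon and moved the read-out hardly at all. Compound 2 also carries an isopropyl on that ring, though it differs from compound 3 in a second place as well. In this assay compound 2 gives 19%, which lies close to the figure of compound 3. Nothing here points to a step beyond the scatter in this assay in either direction.

Compound 4 is therefore expected to give about 19%, with a likely range from 11% to 27%. The expected step from compound 3 is a number 0.8 percentage points higher from compound 3 to compound 4 (within the scatter).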

Compound 4, a percentage reported as inhibition, at one concentration (the size of the read-out at that concentration, not a potency): 14.1%
Compound 4: middle estimate off by 4.9 percentage points, on the high side; the range from low to high includes it.
By their numbers in this assay, from the lowest: compounds 4, 1, 3 and 2 (each within the scatter of the next).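

With isopropyl in place of chloro, a number 4.1 percentage points lower from compound 3 to compound 4 (within the scatter), and with isopropyl in place of methoxy, a number 1.4 percentage points lower from compound 1 to compound 4 (within the scatter), so in this assay chloro, methoxy and isopropyl on this aromatic carbon, para to a large group, cannot be told apart. The second place now has a step of its own: methyl in place of hydrogen on the saturated chain carbon bound to the aromatic nitrogen gives a number 4.9 percentage points lower from compound 2 to compound 4 (within the scatter), so that change cannot be told from the scatter either. Neither place has yet produced a step beyond the scatter, so all four compounds remain together at this one concentration, and nothing at hand bears on why these figures fall as they do.

What the compounds shown leave open is whether an amine or a carboxylic acid on that aromatic carbon, or a longer chain on the aromatic nitrogen, would move the read-out beyond the scatter. They also leave open how these compounds would rank at other concentrations, since a figure at one concentration is not a potency.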